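A few compounds are considered here, and "the series" means these few. Any claim that something is new, unique, unknown or untested is made for them only; others in the source may bear on it.

Compound 1 `CCC1(Cc2ccccc2)OS(=O)(=O)C=C1OCc1ccc(OC)cc1` was tested in an ADME assay on HEL cells (Homo sapiens) for cytotoxicity, with a stated time of 3 days; a lower number here means that less compound is tolerated, a higher number that more compound is tolerated. In this assay compound 1 gives >= 200000 nM, which is a limit of the assay and not a number. Compound 2 `CCC1(Cc2ccccc2)OS(=O)(=O)C=C1OCCCCCCc1ccccc1` went through the same test. In this assay compound 2 gives >= 20000 nM, again only a limit. Going by the values given here, compound 1 therefore stands at a limit, and the one other value shown is a limit as well, so no order between them can be read. Compound 3 `CCC1(Cc2ccccc2)OS(=O)(=O)C=C1OCC=C(C)C` differs from compound 1 by 2-methylprop-1-en-1-yl in place of 4-methoxyphenyl on a saturated chain carbon bound to an oxygen on an unsaturated carbon. Among the compounds with values here, no step between measured compounds is known; the step expected here, an at least 2.0-fold lower number from compound 1 to compound 3 (0.30 log units; that floor lies within the scatter), is none beyond the usual scatter. Compound 3 is expected to give 100000 nM in this assay, between 30000 nM and 200000 nM.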

Compound 3, minimum cytotoxic concentration: 400000 nM
Compound 3: middle estimate off by 4.0-fold (0.60 log units), on the low side, and the stated range ends below it.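

Going by these compounds alone, no step from compound 1 to compound 3 can be read in this assay: the value of compound 1 is a limit and not a number. The compounds shown leave open how far 2-methylprop-1-en-1-yl in place of 4-methoxyphenyl shifts the tolerated concentration, and in which direction.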